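The source may report more compounds than this note shows. Statements on the series, on what has been measured and on what is new or still open speak of the compounds shown alone.

Three compounds have been measured so far in a functional assay on HepG2 cells (Homo sapiens) for inhibition, read by MTT assay, with a stated time of 3 days (a higher number here means a weaker inhibitor, a lower number a stronger inhibitor), with these results:

- compound 1 `COc1cc(-c2nc3ccccc3s2)ccc1OCC(=O)NNC(=O)CCl` with 2890 nM
- compound 2 `CC[C@H](C)[C@@H](NCC(=O)NNC(=O)COc1ccc(-c2nc3ccccc3s2)cc1OC)C(=O)O` with 3990 nM
- compound 3 `COc1cc(-c2nc3ccccc3s2)ccc1OCC(=O)NNC(=O)CN[C@@H](CS)C(=O)O` with 3120 nM

These values sit close together. Compound 3 stands within the scatter of both others, as its two steps show: a 1.1-fold higher number from compound 1 to compound 3 (0.03 log units; within the scatter) and a 1.3-fold lower number from compound 2 to compound 3 (0.11 log units; within the scatter). No order can be read among the three.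

The next compound, compound 4 `COc1cc(-c2nc3ccccc3s2)ccc1OCC(=O)NNC(=O)CN(C(C)=O)[C@@H](CS)C(=O)O`, matches compound 3 except for one spot, with acetyl in place of hydrogen on an amine nitrogen. The closest evidence comes from the other changes at this part of the molecule. Swapping chloro for an amino group gave a 1.4-fold higher number from compound 1 to compound 2 (0.14 log units; within the scatter) as well as the step to compound 3 already shown. Changing the group on the amine nitrogen also stayed within the scatter. Within the data shown here, none of the measured compounds carries acetyl on this nitrogen, so the evidence is indirect and the range must stay wide.

No step beyond the scatter is therefore expected in this assay, in either direction. The estimated step is a 1.1-fold higher number from compound 3 to compound 4 (0.04 log units; within the scatter) and no more than that is expected. Compound 4 is estimated at 3400 nM with an expected range from 1500 nM to 8000 nM in this measurement.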

Compound 4, half-maximal inhibitory concentration: 3420 nM
Beside the measured number, compound 4's estimate is 1.0-fold (0.00 log units) below it, and the stated range covers the measured number.
By their numbers in this assay, from the lowest: compounds 1, 3, 4 and 2 (each within the scatter of the next).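

Compound 4 shows that the amine nitrogen, which carries a hydrogen in compound 3, can also carry acetyl, a group of 3 heavy atoms, without a step beyond the scatter in this assay: the result is a 1.1-fold higher number from compound 3 to compound 4 (0.04 log units; within the scatter). The comparisons with the other two compounds, which change the whole group on the saturated chain carbon, also stay within the scatter, with a 1.2-fold lower number from compound 2 to compound 4 (0.07 log units; within the scatter) and a 1.2-fold higher number from compound 1 to compound 4 (0.07 log units; within the scatter), so the four compounds still show no order among themselves. No measurement is available that could explain why these numbers stay so close together.

From the compounds shown here alone, it remains open whether a plain methyl, a benzoyl group or a longer acyl chain on this nitrogen would also stay within the scatter, or whether one of them would give a clearly higher or lower number. Among these compounds, it is equally open whether a methyl ester in place of the carboxylic acid, or a change in the shared core, would produce the first clear step in this assay.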